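A few compounds are considered here, and "the series" means these few. Any claim that something is new, unique, unknown or untested is made for them only; others in the source may bear on it.

Within the data shown here, compound 3 `COc1ccccc1-c1ccc([C@H]2S[C@@H](C)C(=O)Nc3c2c(C)nn3-c2ccccc2C)cc1` is one of three compounds measured in an assay on isolated protein for agonist activity at Bile acid receptor (Homo sapiens), read by AlphaScreen, with a stated time of 30 min (on this read-out lower numbers stand for smaller maximal responses and higher numbers for larger maximal responses), where compound 3 gives 50%. That is the second highest of the three numbers: compound 1 `CCCc1ccccc1-n1nc(C)c2c1NC(=O)[C@H](C)S[C@@H]2c1ccc(Oc2ccccc2)cc1` gives 240%, and compound 2 `Cc1ccccc1-n1nc(C)c2c1NC(=O)[C@H](C)S[C@@H]2c1ccc(-c2cc3ccccc3o2)cc1` gives 17%. Compound 4 `COc1ccccc1Oc1ccc([C@H]2S[C@@H](C)C(=O)Nc3c2c(C)nn3-c2ccccc2C)cc1` has not yet been measured; it differs from compound 3 by 2-methoxyphenoxy in place of 2-methoxyphenyl on an aromatic carbon. Among the measured compounds shown here, one measured step touches the same place, and it was large: a number 33 percentage points higher from compound 2 to compound 3 (beyond the scatter). Compound 1 gives a far larger response than compound 3, but the two differ in more than one place, so no single step can be read from them. On this thin basis a rise beyond the scatter is expected, a number 50 percentage points higher from compound 3 to compound 4 (beyond the scatter). Compound 4 is estimated at 100%, between 40% and 200%.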

Compound 4, largest response reached (reported as efficacy), in percent of the reference or control that the assay uses: 240%
The estimate for compound 4 lay 140 percentage points below the measured number, and the stated range ends below it.
By their numbers in this assay, from the lowest: compound 2; then compound 3; then compounds 1 and 4 (each within the scatter of the next).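

In this assay there is a number 190 percentage points higher from compound 3 to compound 4 (beyond the scatter) when 2-methoxyphenoxy replaces 2-methoxyphenyl on this aromatic carbon, so a small change in the group at this place can alter the maximal response greatly. There is also a number 223 percentage points higher from compound 2 to compound 4 (beyond the scatter) when 2-methoxyphenoxy replaces 1-benzofuran-2-yl, far more than the earlier swap of that group for 2-methoxyphenyl gave. Nothing available explains why the response changes so strongly.

The compounds shown leave open how an amine or a carboxylic acid at this place would behave. They also leave open whether the methoxy group of 2-methoxyphenoxy contributes to the response on this core.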